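The compounds below may be only part of what the source reports. "The series", "measured", "known", "first", "only" and "open" are said of these compounds alone.

Three compounds have been measured in a functional assay on DWD cells (Homo sapiens) for inhibition, read by sulforhodamine B assay (on this read-out lower numbers stand for stronger inhibition of growth and higher numbers for weaker inhibition of growth), so far:

Compound 1 (`c1ccc(-c2ccc(-c3ccc(-c4nc5ccccc5[nH]4)cc3)cc2)cc1`) gives 100000 nM
Compound 2 (`Cc1ccc2[nH]c(-c3ccc(-c4ccc(-c5cccc(Cl)c5)cc4)cc3)nc2c1`) gives 2510 nM
Compound 3 (`COc1cc(-c2ccc(-c3ccc(-c4nc5cc(C)ccc5[nH]4)cc3)cc2)cc(OC)c1OC`) gives 170 nM

Compound 1 has the highest number of the three, beyond the scatter from both others. Compound 4 (`FC(F)(F)c1ccc(-c2ccc(-c3ccc(-c4nc5ccccc5[nH]4)cc3)cc2)cc1`) has trifluoromethyl in place of hydrogen on an aromatic carbon of compound 1, para to a large group (trifluoromethyl in place of hydrogen on an aromatic carbon). Within the data shown here, no measured pair isolates this change. Compound 2 (2510 nM) and compound 3 (170 nM) both carry added groups and show lower numbers, although they also differ elsewhere. A drop beyond the scatter is therefore expected in this assay, with an estimated size of a 17-fold lower number from compound 1 to compound 4 (1.22 log units; beyond the scatter) and wide uncertainty. For compound 4 the estimated value is 6000 nM (expected range 1000 nM to 40000 nM).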

Compound 4, concentration for 50% growth inhibition: 100000 nM
For compound 4 the middle estimate is 17-fold (1.22 log units) below the measured one; measured number above the stated range.
By their numbers in this assay, from the lowest: compound 3; then compound 2; then compounds 1 and 4 (each within the scatter of the next).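

In this assay, trifluoromethyl in place of hydrogen on an aromatic carbon, para to a large group, gives no change at the digits printed from compound 1 to compound 4 (within the scatter). Among these compounds, this is the first reading of a single change on this core, and it shows that this group at this position does not by itself move the number. Nothing at hand explains this result.

As far as these compounds go, whether an amine or a carboxylic acid at the same position would move the number remains open. So does whether trifluoromethyl would act the same way on a core with other changes.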